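Methoxy Additions on Two Related Cores Against Liver Cancer Cells

This account rests on a few compounds, and the source may have more. Where it says the series, first, only, none or still open, it means among the compounds named here.

Measured so far:
compound 1, `COc1ccc(-c2ccc3c(c2)C(=O)C(=O)N3Cc2cccc(OC)c2)cc1`: 700 nM
compound 2, `COc1ccc(-c2ccc3c(c2)C(=O)C(=O)N3Cc2ccc(OC)c(OC)c2)cc1`: 1350 nM
compound 3, `COc1ccc(CN2C(=O)C(=O)c3cc(-c4cccc(OC)c4)ccc32)cc1`: 1890 nM

In a functional assay on HepG2 cells (Homo sapiens) for antiproliferative activity, read by MTT assay, with a stated time of 48 h (on this read-out lower numbers stand for stronger inhibition and higher numbers for weaker inhibition), compound 1 gives 700 nM and compound 2 gives 1350 nM. The change between them is methoxy in place of hydrogen on an aromatic carbon, and it made a 1.9-fold higher number from compound 1 to compound 2 (0.29 log units; within the scatter). Compound 3 has the same atoms as compound 1 joined differently; the difference between the two cores is not broken down here. In this assay compound 3 gives 1890 nM, which beside compound 2 lies within the scatter, while beside compound 1 it is the higher number by more than the scatter.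

Compound 4, `COc1ccc(CN2C(=O)C(=O)c3cc(-c4cc(OC)cc(OC)c4)ccc32)cc1`, has not yet been measured. It differs from compound 3 by methoxy in place of hydrogen on an aromatic carbon. This is the same kind of change as that from compound 1 to compound 2, not the same: in compound 2 the entering methoxy sits ortho to a methoxy group and para to a large group, whereas in compound 4 it sits meta to a large group and meta to a methoxy group. Among the measured compounds shown here, only one earlier step is available, so the expectation is thin. Because the earlier pair showed a 1.9-fold higher number from compound 1 to compound 2 (0.29 log units; within the scatter), a step of a 1.6-fold higher number from compound 3 to compound 4 (0.20 log units; within the scatter) is expected in this assay. Compound 4 is therefore estimated at 3000 nM, with a likely range from 1300 nM to 7000 nM.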

Compound 4, half-maximal inhibitory concentration: 1200 nM
Estimate against measurement, compound 4: 2.5-fold (0.40 log units) above, outside the stated range (below it).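

In this assay the new step is a 1.6-fold lower number from compound 3 to compound 4 (0.20 log units; within the scatter), and set beside the earlier step, the same change does not carry over unchanged from one core to the other: the same change on two cores in this assay, a 1.9-fold higher number (0.29 log units; within the scatter) from compound 1 to compound 2 and a 1.6-fold lower number (0.20 log units; within the scatter) from compound 3 to compound 4, 3.0-fold (0.48 log units) apart, beyond the scatter of two such steps

For these two pairs, then, the step seen on the core of compound 1 was no reliable guide to the step on the core of compound 3. Among the compounds shown here, it does not show that the methoxy truly raises the number on one core and lowers it on the other: each step taken alone lies within the scatter, only two pairs are available, and the entering methoxy sits in a different place in each, in compound 4 meta to a large group and meta to a methoxy group, so the effect of the core cannot be separated from that of the place.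

All the substituents on the aromatic rings shown are methoxy groups, which leaves open how a hydroxyl, an amine or a carboxylic acid would read on either core. Going by these compounds, it also remains open whether the two cores would still part if a methoxy entered at the same place on both.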